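A few compounds are considered here, and "the series" means these few. Any claim that something is new, unique, unknown or untested is made for them only; others in the source may bear on it.

Compound 1 `CCn1c([C@@H](C)NS(=O)(=O)c2ccc(Cl)cc2)nc2ccc(C(F)(F)F)cc21` gives > 100 mL.min-1.g-1 as a limit.
Compound 2 `CCn1c([C@@H](C)NS(=O)(=O)c2c(F)cc(F)cc2F)nc2ccc(C(F)(F)F)cc21` gives 19 mL.min-1.g-1 as a measured number.
Compound 3 `CCn1ncc(S(=O)(=O)N[C@H](C)c2nc3ccc(C(F)(F)F)cc3n2CC)c1C` gives > 100 mL.min-1.g-1 as a limit.

All three values come from an ADME assay (liver) for metabolic stability, with Liver microsome (Homo sapiens) as the target, read by LC-MS, using microsomes and NADPH, with a stated time of 5 min, at 37 degrees C (a lower number here means slower removal, a higher number faster removal of the compound), alone. Compound 3 stands at the limit of > 100 mL.min-1.g-1 in this assay, at which 2 of the 3 values shown sit, and has no exact number. Compound 4 `CCn1c([C@@H](C)NS(=O)(=O)c2cnn(C(C)C)c2C)nc2ccc(C(F)(F)F)cc21` differs from compound 3 by methyl in place of hydrogen on a saturated chain carbon bound to an aromatic nitrogen and a saturated chain carbon and so turns ethyl to isopropyl. The measured steps all replace the whole group on the sulfonyl sulfur: an at least 5.2-fold lower number from compound 1 to compound 2 (0.72 log units; beyond the scatter) and an at least 5.2-fold higher number from compound 2 to compound 3 (0.72 log units; beyond the scatter) lie beyond the scatter, while a step that the two limits leave unreadable from compound 1 to compound 3 cannot be sized. None measures this methyl change. Starting from compound 3 at the limit of > 100 mL.min-1.g-1 in this assay, at which 2 of the 3 values shown sit, no step beyond the scatter is expected in this assay for this change. The estimate means a step that the limit leaves unreadable from compound 3 to compound 4 as the expected step. For compound 4 the estimated value is 120 mL.min-1.g-1 with an expected range of 60 mL.min-1.g-1 to 300 mL.min-1.g-1 overall.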

Compound 4, intrinsic clearance in microsomes: > 100 mL.min-1.g-1
Compound 4: a limit, no number; the forecaster's own chance of this, stated with the estimate: 75%; the middle value does not contradict the limit.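

In this assay compound 4 gives > 100 mL.min-1.g-1, a limit and not a number. With 1-isopropyl-5-methyl-1H-pyrazol-4-yl on the sulfonyl sulfur, a second pyrazolyl group stands clearly apart from the 2,4,6-trifluorophenyl group, with an at least 5.2-fold higher number from compound 2 to compound 4 (0.72 log units; beyond the scatter). The steps to compound 4 from compound 3 and from compound 1 cannot be read: the limit of > 100 mL.min-1.g-1 in this assay, at which 3 of the 4 values shown sit.

Going by these compounds, whether the added methyl shifts clearance at all stays open, with compound 3 and compound 4 both at a limit. Also open, on these data alone, is how a cyclopropyl group or a carboxylic acid in place of the isopropyl would read in this assay.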